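Methoxy for methyl on the aryl ring of compound 3

A few compounds are considered here, and "the series" means these few. Any claim that something is new, unique, unknown or untested is made for them only; others in the source may bear on it.

Measured compounds:
compound 1 `Cc1cc(-c2cccc(F)c2)nnc1N1CCN(c2ncccn2)CC1` 33500 nM
compound 2 `Cc1cc(-c2ccc(C(F)(F)F)cc2)nnc1N1CCN(c2ncccn2)CC1` 37400 nM
compound 3 `Cc1ccc(-c2cc(C)c(N3CCN(c4ncccn4)CC3)nn2)cc1` 17200 nM

In a functional assay on BV-2 cells (Mus musculus) for inhibition, read by ELISA, with a stated time of 16 h (a lower number here means a stronger inhibitor, a higher number a weaker inhibitor), compound 3 gives the lowest of the three numbers. Its nearest neighbour is compound 1, and the step of a 1.9-fold lower number from compound 1 to compound 3 (0.29 log units; within the scatter) is within the scatter, so the two cannot be ordered. Compound 2 stands furthest away; the step of a 2.2-fold lower number from compound 2 to compound 3 (0.34 log units; beyond the scatter) is modest but beyond the scatter.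

Compound 4 `COc1ccc(-c2cc(C)c(N3CCN(c4ncccn4)CC3)nn2)cc1` differs from compound 3 in one place: methoxy in place of methyl on an aromatic carbon

Among the measured compounds shown here, no measured step touches a methoxy group, so nothing bears directly on this change. The two steps that do exist, a 1.9-fold lower number from compound 1 to compound 3 (0.29 log units; within the scatter) and a 2.2-fold lower number from compound 2 to compound 3 (0.34 log units; beyond the scatter), show that changes at this aryl ring moved the numbers in this assay only a little, at or just beyond the scatter. On that basis a step of similar, small size is expected for compound 4, with no direction that can be called reliably: a 1.1-fold lower number from compound 3 to compound 4 (0.06 log units; within the scatter).

Compound 4 is therefore estimated at 15000 nM in this assay, with a range of 6000 nM to 40000 nM.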

Compound 4, half-maximal inhibitory concentration: 5200 nM
The estimate for compound 4 lay 2.9-fold (0.46 log units) above the measured number, and the stated range ends above it.
By their numbers in this assay, from the lowest: compound 4; then compounds 3, 1 and 2 (each within the scatter of the next, the first and the last beyond it).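

In this assay, among the compounds shown here, the aryl ring no longer looks like a place where changes hardly register: methoxy in place of methyl, para to a large group, gives a 3.3-fold lower number from compound 3 to compound 4 (0.52 log units; beyond the scatter), whereas the earlier steps here stayed at or just beyond the scatter. Compound 4 also separates from the other two compounds, with a 7.2-fold lower number from compound 2 to compound 4 (0.86 log units; beyond the scatter) and a 6.4-fold lower number from compound 1 to compound 4 (0.81 log units; beyond the scatter), which makes it the strongest inhibitor of the four, since all its steps are printed as beyond the scatter. The gain comes from a swap that adds one oxygen and one hydrogen-bond acceptor to the substituent, but no measurement offered here accounts for the lower number.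

Going by these compounds, whether a hydroxyl, an ethoxy chain or a dimethylamino group at the same place would lower the number further remains open, and so does whether the oxygen itself matters or the larger substituent would do as well. On these data alone, it is equally open whether a methoxy group elsewhere on the ring would give a step of similar size, and whether the step would carry over to a read-out other than this one.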